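The source may report more compounds than this note shows. Statements on the series, on what has been measured and on what is new or still open speak of the compounds shown alone.

Measured compounds in a functional assay on MCF7 cells (Homo sapiens) for inhibition, read by MTT assay, with a stated time of 72 h; on this read-out higher numbers stand for weaker inhibition and lower numbers for stronger inhibition:

Compound 1, `Nc1nc2cc(-c3nn(CCCC(=O)NO)c4ncnc(N)c34)ccc2o1`, gives > 50000 nM, which is a limit of the assay and not a number.
Compound 2, `Nc1ncnc2c1c(-c1cnc3[nH]ccc3c1)nn2CCCCCC(=O)NO`, gives > 150000 nM, again a limit.
Compound 3, `Nc1ncnc2c1c(-c1cnc3[nH]ccc3c1)nn2CCCC(=O)NO`, gives > 150000 nM, again a limit.

Compound 1 stands only at a limit in this assay; the two other values shown are limits as well, so no ranking among the three is possible. The step that the two limits leave unreadable from compound 2 to compound 3 runs between two limits and cannot be read, so it gives no measured size for a change in chain length.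

Compound 4, `Nc1nc2cc(-c3nn(CCCCCCC(=O)NO)c4ncnc(N)c34)ccc2o1`, has not yet been measured. It differs from compound 1 as 3-(hydroxycarbamoyl)propyl in place of hydroxycarbamoyl on a saturated chain carbon, three bonds along the chain from an aromatic nitrogen. Within the data shown here, no measured step bears on this change with a readable size, since both values of the only comparable pair sit at the limit of > 150000 nM in this assay, at which 2 of the 3 values shown sit. Compound 1 itself sits at the limit of > 50000 nM in this assay, at which 1 of the 3 values shown sits. The expectation for compound 4 therefore rests on weak ground; the step of an at least 1.2-fold lower number from compound 1 to compound 4 (0.09 log units; that floor lies within the scatter) is an estimate only, with a fair chance that this assay again reports only a limit. Compound 4 is expected near 40000 nM, within 5000 nM to 150000 nM.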

Compound 4, half-maximal inhibitory concentration: 11900 nM
The estimate for compound 4 lay 3.4-fold (0.53 log units) above the measured number, and the stated range covers the measured number.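

Working from this assay, replacing hydroxycarbamoyl with 3-(hydroxycarbamoyl)propyl on a saturated chain carbon, three bonds along the chain from an aromatic nitrogen, gives the first readable step in the series: an at least 4.2-fold lower number from compound 1 to compound 4 (0.62 log units; beyond the scatter). Compound 4 gives a true number, 11900 nM, so the longer chain on this core brings the read-out within measurable range. The step is only a floor, as the value of compound 1 is a limit and not a number: the limit of > 50000 nM in this assay, at which 1 of the 4 values shown sits.

Going by these compounds, the step between compound 2 and compound 3 cannot be read, so it remains open whether chain length matters with the aromatic group those two compounds carry. Also open, on these data alone, is whether a chain longer than 6-(hydroxycarbamoyl)hexyl, or a carboxylic acid in place of the hydroxycarbamoyl end, would keep a measurable number.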